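Compound 2 loses its octylsulfanyl group

The source may report more compounds than this note shows. Statements on the series, on what has been measured and on what is new or still open speak of the compounds shown alone.

Compound 1 `CC1=CCC[C@H]2[C@](C)(CC3=CC(=O)C(SC(C)(C)C)=CC3=O)[C@@H](C)CC[C@]12C`: 20800 nM
Compound 2 `CCCCCCCCSC1=CC(=O)C(C[C@]2(C)[C@@H](C)CC[C@]3(C)C(C)=CCC[C@@H]23)=CC1=O`: "not determined" (no result reported)

Both compounds went through an ADME assay on PBMC cells (Homo sapiens) for inhibition, read by MTT assay (on this read-out lower numbers stand for stronger inhibition and higher numbers for weaker inhibition), but only compound 1 gave a number, and that number is 20800 nM on this scale. Compound 2 has no place on the same scale, as its entry reads "not determined" (no result reported) and offers no single figure to start from.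

Compound 3 `CC1=CCC[C@H]2[C@](C)(CC3=CC(=O)C=CC3=O)[C@@H](C)CC[C@]12C` has not yet been measured. The structural change is hydrogen in place of octylsulfanyl on a double-bonded ring carbon and in words it is hydrogen in place of octylsulfanyl on a double-bonded ring carbon. Going by the values given here, no step between measured compounds exists to show what such a change does, so the size of the step from compound 2 cannot be read from the data. Among the compounds with values here, the only anchor is compound 1 at 20800 nM and compound 3 is expected to fall near it, with no shift beyond the scatter in either direction. In this assay compound 3 is expected at 18000 nM with an estimated range from 7000 nM to 45000 nM as its likely span.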

Compound 3, half-maximal inhibitory concentration: 4500 nM
Compound 3: middle estimate off by 4.0-fold (0.60 log units), on the high side; the whole stated range lies above it.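

In this assay, going by these compounds alone, the one readable change at this double-bonded ring carbon is a 4.6-fold lower number from compound 1 to compound 3 (0.66 log units; beyond the scatter) and it shows that the shared core needs no sulfur-linked group here to reach the stronger inhibition of compound 3. A bare hydrogen on this carbon, three ring bonds from the ring atom that bears the large group, therefore goes with stronger inhibition than (tert-butyl)sulfanyl does, on the evidence of this single pair. Compound 2 gives no number, so the step from octylsulfanyl to hydrogen cannot be read, and nothing at hand accounts for the size of the step from (tert-butyl)sulfanyl to hydrogen.

On these data alone, it stays open whether the octylsulfanyl chain of compound 2 would sit near compound 1 or somewhere else on this scale. Also open, as far as these compounds go, is whether a smaller sulfur-linked group such as methylsulfanyl, or an amine or a carboxylic acid on the same ring carbon, would stay with compound 3 or move toward compound 1.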